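The compounds below may be only part of what the source reports. "The series", "measured", "known", "first", "only" and "open" are said of these compounds alone.

Measured compounds:
compound 1, `CCCCc1oc2ccccc2c1C(=O)c1ccc(OCCCC(=O)NCc2ccccc2)cc1`, > 50000 nM
compound 2, `CCCCc1oc2ccccc2c1C(=O)c1ccc(OCCCC(=O)N[C@@H](C)c2ccccc2)cc1`, > 50000 nM
compound 3, `CCCCc1oc2ccccc2c1C(=O)c1cc(I)c(OCCCN2CCN(C)CC2)c(I)c1`, 8760 nM

Of the compounds shown here, three have been tested in a functional assay on MDA-MB-231 cells (Homo sapiens) for antiproliferative activity, read by MTT assay, with a stated time of 24 h; on this read-out lower numbers stand for stronger inhibition and higher numbers for weaker inhibition. Compound 1 gives > 50000 nM, which is a limit of the assay and not a number. Compound 2 likewise gives > 50000 nM, again a limit rather than a number. Going by the values given here, compound 3 is the only one with a real number, 8760 nM. How the core of compound 3 differs from the core of compound 1 is not broken down here.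

Compound 1 and compound 2 differ in one place, described as methyl in place of hydrogen on a saturated chain carbon bound to an amide-type nitrogen and an aromatic carbon. Because both values sit at the limit of > 50000 nM in this assay, at which 2 of the 3 values shown sit, the step that the two limits leave unreadable from compound 1 to compound 2 cannot be read.

Compound 4, `CCCCc1oc2ccccc2c1C(=O)c1cc(I)c(OCCCN2CCN(CC)CC2)c(I)c1`, has not yet been measured in this assay. It differs from compound 3 by methyl in place of hydrogen on a saturated chain carbon bound to an amine nitrogen in a ring. This is the same kind of change as that from compound 1 to compound 2, but not the same: there the methyl entered on a saturated chain carbon bound to an amide-type nitrogen and an aromatic carbon, here on a saturated chain carbon bound to an amine nitrogen in a ring. The earlier step gives no readable size, so the expectation rests on compound 3 alone, with its value of 8760 nM. A small step of a 1.1-fold lower number from compound 3 to compound 4 (0.04 log units; within the scatter) is expected. Compound 4 is estimated to give 8000 nM, within a range from 3000 nM to 22000 nM.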

Compound 4, half-maximal inhibitory concentration: 18000 nM
For compound 4 the middle estimate is 2.3-fold (0.35 log units) below the measured one; measured number inside the range.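

In this assay putting methyl in place of hydrogen on a saturated chain carbon bound to an amine nitrogen in a ring, which turns 4-methylpiperazin-1-yl into 4-ethylpiperazin-1-yl, gives a 2.1-fold higher number from compound 3 to compound 4 (0.31 log units; beyond the scatter) and so means a modest loss of inhibition on this core. This is one readable step on one core, and it does not show whether the change carries over to another core, either in size or in direction. The related methyl on the chain carbon bound to an amide-type nitrogen and an aromatic carbon offers no comparison, because compound 1 and compound 2 both rest on a limit and not on a number: the limit of > 50000 nM in this assay, at which 2 of the 4 values shown sit.

The compounds shown leave open whether a longer chain in place of the ethyl of 4-ethylpiperazin-1-yl would raise the number further, or whether a carboxylic acid at that place would move it the other way. A single step cannot establish a trend, and comparing this change across cores would need a pair on the core of compound 1 with readable numbers on both sides.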